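Swapping a sulfonyl substituent on a urea-linked activator

A few compounds are considered here, and "the series" means these few. Any claim that something is new, unique, unknown or untested is made for them only; others in the source may bear on it.

Compound 1 `CNS(=O)(=O)c1ccc(NC(=O)NCc2ccncc2)cc1` is a small urea that was tested in an assay on isolated protein for activation of Nicotinamide phosphoribosyltransferase (Homo sapiens) (on this read-out higher numbers stand for an effect only at larger amounts of compound and lower numbers for an effect already at smaller amounts), where compound 1 gives 3230 nM. Among the three measured compounds it stands second highest. Compound 2 `CCOC(=O)c1ccc(NC(=S)NCc2ccncc2)cc1` gives 9770 nM, the higher number of the two, a gap beyond the usual scatter. Compound 3 `O=C(NCc1cnco1)Nc1ccc(S(=O)(=O)c2ccccc2)cc1`, which carries a phenylsulfonyl group in place of the sulfonamide, gives 77 nM, a far lower number, again a gap well beyond the scatter.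

Compound 4 `O=C(NCc1ccncc1)Nc1ccc(S(=O)(=O)c2ccccc2Cl)cc1` has not been measured. It differs from compound 1 in one place: 2-chlorophenyl in place of methylamino on a sulfonyl sulfur. This change brings compound 4 close to the sulfonyl pattern of compound 3 while keeping the pyridinylmethyl urea of compound 1.

Among the measured compounds shown here, no direct one-change step between measured compounds exists, so the expectation rests on the contrast between compound 1 and compound 3. Compound 4 is expected to land at 150 nM, with a likely range from 40 nM to 600 nM, because compound 3 reaches 77 nM with a related aryl sulfone. That implies an estimated downward step a 22-fold lower number from compound 1 to compound 4 (1.33 log units; beyond the scatter) beyond the scatter.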

Compound 4, half-maximal effective concentration: 79 nM
Compound 4: the middle estimate sits 1.9-fold (0.28 log units) above what was measured; measured number inside the range.
By their numbers in this assay, from the lowest: compounds 3 and 4 (each within the scatter of the next); then compound 1; then compound 2.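

In this assay the exchange of methylamino for 2-chlorophenyl on a sulfonyl sulfur gives a large step (a 41-fold lower number from compound 1 to compound 4 (1.61 log units; beyond the scatter)), while the pyridinylmethyl urea stays as it is. Among the compounds shown here, this shows that the group on the sulfonyl sulfur can by itself move the number far, something the earlier compounds could not show, as no two of them differ in one place only. Nothing measured here explains why the step is so large.

The change removes a hydrogen-bond donor and adds an aromatic ring and a chlorine all at once, so the compounds shown do not separate the parts of this swap. From the compounds shown here alone, whether the ring, the chlorine or the loss of methylamino carries the step stays open, and a plain methyl or a cyclohexyl on the same sulfur would be informative.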